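A few compounds are considered here, and "the series" means these few. Any claim that something is new, unique, unknown or untested is made for them only; others in the source may bear on it.

Compound 1 `Cc1cc(CN(CC2CC2)C(CC(=O)O)c2ccc(Cl)cc2)ccc1OCCn1c(=O)ccn(C)c1=O` gives 24%
Compound 2 `CCCN(Cc1ccc(OCCn2c(=O)ccn(C)c2=O)c(OC)c1)C(CC(=O)O)c1ccc(Cl)cc1` gives 50%

Going by the values given here, both values come from an ADME assay on liver (Mus musculus) for metabolic stability, read by LC-MS, using microsomes and NADPH (a higher number here means that more of the compound is left, a lower number that less of the compound is left), and are the only measurements so far. Compound 2 stands higher of the two at 50% in this test, while compound 1 lies at 24% on the same scale, a gap beyond the usual scatter.

The next molecule, compound 3 `COc1cc(CN(CC2CC2)C(CC(=O)O)c2ccc(Cl)cc2)ccc1OCCn1c(=O)ccn(C)c1=O`, differs from compound 2 in one place: cyclopropyl in place of ethyl on a saturated chain carbon bound to an amine nitrogen, which turns propyl into cyclopropylmethyl cyclopropyl in place of ethyl on a saturated chain carbon bound to an amine nitrogen for the count of atoms. Among the compounds with values here, no measured pair differs in just one place, so this change has no direct precedent in the data. Within the data shown here, the only hint is that compound 1, which also carries cyclopropylmethyl, gives 24% in this assay, and this points to a modest fall rather than a rise. The expected change is a number 12 percentage points lower from compound 2 to compound 3 (beyond the scatter) in the percent remaining. For compound 3 the estimate is 38% with an expected range from 20% to 58% as its limits.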

Compound 3, percent of the compound remaining: 42%
The estimate for compound 3 lay 4 percentage points below the measured number; the measured number falls inside the stated range.
By their numbers in this assay, from the lowest: compound 1; then compounds 3 and 2 (each within the scatter of the next).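

In this assay, going by these compounds alone, cyclopropyl in place of ethyl on a saturated chain carbon bound to an amine nitrogen gives a number 8 percentage points lower from compound 2 to compound 3 (within the scatter), so this change, now seen on its own for the first time, cannot be told apart from ordinary repeat-to-repeat variation. With cyclopropylmethyl kept in both molecules, methoxy in place of methyl on an aromatic carbon gives a number 18 percentage points higher from compound 1 to compound 3 (beyond the scatter), a modest step but one that clears the scatter, making it the only one of the two single changes with a readable effect on the percent remaining. Within the data shown here, nothing measured so far offers an explanation for either step.

The compounds shown leave open whether the methoxy-for-methyl step would keep its size with propyl in the molecule instead of cyclopropylmethyl, as each single change is seen against only one background. They also leave open how a longer chain such as butyl in place of propyl, or ethoxy in place of methoxy, would behave in this assay.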